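A few compounds are considered here, and "the series" means these few. Any claim that something is new, unique, unknown or untested is made for them only; others in the source may bear on it.

Working notes on the series built on the shared core of compound 1 `CCCOCCn1c(N2CCN(C)CC2)nc2ccccc21`. For the measured compounds named here, in a functional assay on ileum for inhibition of histamine H1 receptor (Cavia porcellus) (on this read-out higher numbers stand for weaker inhibition and lower numbers for stronger inhibition), compound 1 gives 20 nM, the only plain number among the three values shown. Compound 2 `CCOCCn1c(N2CCN(C(c3ccccc3)c3ccccc3)CC2)nc2ccccc21` reaches only a limit of the assay, > 3000 nM. Compound 3 `CCOCCn1c(N2CCN(c3ccccc3)CC2)nc2ccccc21` likewise returns only a limit, > 10000 nM. Compound 1 therefore stands alone as the one measured figure; the other two entries are limits, not numbers.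

Compound 4 `CCCn1c(N2CCN(C)CC2)nc2ccccc21` differs from compound 1 in a single place: methyl in place of propoxy on a saturated chain carbon, two bonds along the chain from an aromatic nitrogen. Going by the values given here, no measured pair in the set isolates this change, so its size is not known from the data. The expectation is a moderate loss in this assay, an estimated step of a 3.0-fold higher number from compound 1 to compound 4 (0.48 log units; beyond the scatter), beyond the usual scatter. Compound 4 is expected at 60 nM, in a range from 15 nM to 250 nM.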

Compound 4, half-maximal inhibitory concentration: 380 nM
For compound 4 the middle estimate is 6.3-fold (0.80 log units) below the measured one; the whole stated range lies below it.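

In this assay, this position on the saturated chain proves far from silent: replacing propoxy with methyl gives a 19-fold higher number from compound 1 to compound 4 (1.28 log units; beyond the scatter), the first measured size for any single change in the series. The propoxy group therefore matters to the value of compound 1, although compound 4 still returns a plain number rather than a limit. Nothing shown gives a cause for this step.

This single change removes the oxygen and shortens the chain together, leaving their shares unseparated. A hexyl chain in place of 2-propoxyethyl would address that question, while a terminal amine on the chain remains an open alternative.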